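The source may hold more compounds than are shown below. What is called first, only, known or untested is meant among the compounds shown, and "the series" means these compounds.

Within the data shown here, compound 2 `CC(C)(Oc1ccc(F)cc1[N+](=O)[O-])C1OCC(C/C=C\CCC(=O)O)C(c2cccnc2)O1` gives the lower of the two numbers known so far in an assay for inhibition of Thromboxane-A synthase (Homo sapiens), using microsomes (a higher number here means a weaker inhibitor, a lower number a stronger inhibitor), at 20 nM; compound 1 `Cc1ccc(OC(C)(C)C2OCC(C/C=C\CCC(=O)O)C(c3cccnc3)O2)cc1` gives 360 nM, and the step of an 18-fold lower number from compound 1 to compound 2 (1.26 log units; beyond the scatter) is the only measured one. Compound 3 `CC(C)(C1OCC(C/C=C\CCC(=O)O)C(c2cccnc2)O1)S(=O)(=O)c1ccccc1` differs from compound 2 by a group of 9 heavy atoms (6 carbon, 2 oxygen, 1 sulfur; one six-membered aromatic ring of carbon only) in place of a group of 11 heavy atoms (6 carbon, 1 nitrogen, 3 oxygen, 1 fluorine; one six-membered aromatic ring of carbon only), on a saturated chain carbon bound to two saturated chain carbons and a saturated ring carbon. That measured step swaps one aryl ether for another and bears only loosely on a change that removes the ether oxygen and brings in a sulfonyl, so the expectation is uncertain and leans toward a weaker inhibitor. Compound 3 is therefore estimated at 200 nM in this assay, between 30 nM and 2000 nM, an expected step of a 10-fold higher number from compound 2 to compound 3 (1.00 log units; beyond the scatter).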

Compound 3, half-maximal inhibitory concentration: 40 nM
Estimate against measurement, compound 3: 5.0-fold (0.70 log units) above; the range from low to high includes it.
By their numbers in this assay, from the lowest: compounds 2 and 3 (each within the scatter of the next); then compound 1.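

In this assay, an aryl ether is not required at this saturated chain carbon: phenylsulfonyl in place of the group carrying the 4-fluoro-2-nitrophenyl ring gives a 2.0-fold higher number from compound 2 to compound 3 (0.30 log units; within the scatter), so the two groups cannot be told apart here. Phenylsulfonyl in place of 4-methylphenoxy gives a 9.0-fold lower number from compound 1 to compound 3 (0.95 log units; beyond the scatter), so two different linkages to the ring reach this low range. Nothing measured here explains either step. As far as these compounds go, whether the aromatic ring on the sulfonyl is needed stays open, since methylsulfonyl could test that. A sulfonamide at this place also remains an open case.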